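A few compounds are considered here, and "the series" means these few. Any claim that something is new, unique, unknown or untested is made for them only; others in the source may bear on it.

Measured compounds:
- compound 1, `CCC(CO)NCc1nc2c(OCC3CCCCC3)cccc2[nH]1`, with 94.3% in an assay on cells for inhibition of interleukin-5 receptor subunit alpha (Mus musculus), read by WST assay, with a stated time of 48 h, tested at 30 uM, in the presence of a further agent that is not named here; on this read-out higher numbers stand for more inhibition at the one concentration tested (going by the name of the read-out) and lower numbers for less inhibition
- compound 2, `OCC(NCc1nc2c(OCC3CCCCC3)cccc2[nH]1)c1ccccc1`, with 77.7% in this assay

Among the compounds with values here, compound 2 stands lowest of the two numbers so far; its nearest neighbour is compound 1, and the step of a number 16.6 percentage points lower from compound 1 to compound 2 (beyond the scatter) lies beyond the usual scatter, so the two compounds can be told apart. Compound 3, `c1ccc(CNCc2nc3c(OCC4CCCCC4)cccc3[nH]2)cc1`, is not yet measured. It differs from compound 2 in one place: hydrogen in place of hydroxymethyl on a saturated chain carbon bound to an amine nitrogen and an aromatic carbon.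

Within the data shown here, no measured step shows this particular change, the loss of a hydroxymethyl group on a saturated chain carbon bound to an amine nitrogen and an aromatic carbon. Among the measured compounds shown here, the only step in hand, a number 16.6 percentage points lower from compound 1 to compound 2 (beyond the scatter), concerns a different exchange, phenyl in place of ethyl, and was modest in size. It therefore gives only a loose guide: single changes at this part of the molecule have so far moved the read-out by a modest amount, downward.

For compound 3 a small further drop is expected, a number 9.7 percentage points lower from compound 2 to compound 3 (within the scatter), with wide uncertainty. Compound 3 is estimated at 68%, within a range from 48% to 88%.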

Compound 3, a percentage reported as inhibition, at one concentration (the size of the read-out at that concentration, not a potency): 49.3%
The estimate for compound 3 lay 18.7 percentage points above the measured number; low and high end bracket the measured number.
By their numbers in this assay, from the lowest: compound 3; then compound 2; then compound 1.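

In this assay, taking the hydroxymethyl group off the saturated chain carbon bound to an amine nitrogen and an aromatic carbon gives a number 28.4 percentage points lower from compound 2 to compound 3 (beyond the scatter) and so this group, absent from the earlier comparison, now has a measured step of its own. Benzyl in place of 1-(hydroxymethyl)propyl on the amine nitrogen gives a number 45 percentage points lower from compound 1 to compound 3 (beyond the scatter) and this is the only large step so far, with both compounds that keep a hydroxymethyl group reading higher than the one without it. Nothing available explains what lies behind these steps.

From the compounds shown here alone, what stays open is whether the oxygen counts or only the extra carbon: a methyl group or a methoxymethyl group on that same chain carbon would tell these two apart. Also open, going by these compounds, is how much of the high number of compound 1 rests on its hydroxymethyl group, which a plain propyl group on the amine nitrogen in place of 1-(hydroxymethyl)propyl would test.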